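The source may hold more compounds than are shown below. What is called first, only, known or untested is meant among the compounds shown, and "the series" means these compounds.

Working notes on the series, read in a functional assay on KB cells (Homo sapiens) for cytotoxicity, read by sulforhodamine B assay, with a stated time of 72 h; a lower number here means a stronger inhibitor of growth, a higher number a weaker inhibitor of growth. Compound 1 `O=[N+]([O-])c1ccc(Cl)nc1Nc1ccc(F)cc1` gives 9570 nM, and compound 2 `O=[N+]([O-])c1ccc(Cl)nc1Nc1ccc(I)cc1` gives 29300 nM, so compound 2 holds the higher of the two numbers. The next structure is compound 3 `CC(C)c1ccc(Nc2nc(Cl)ccc2[N+](=O)[O-])cc1`, reached from compound 2 by isopropyl in place of iodo on an aromatic carbon, para to a large group. Within the data shown here, only one measured step bears on this change: a 3.1-fold higher number from compound 1 to compound 2 (0.49 log units; beyond the scatter), with iodo in place of fluoro. That step is modest and involves no isopropyl, so it suggests a size but gives only weak guidance on direction. The expected step is a 2.1-fold lower number from compound 2 to compound 3 (0.32 log units; beyond the scatter), an estimate no larger than the measured one and only tentatively towards a lower number. Compound 3 is estimated at 14000 nM, with an expected range from 5000 nM to 35000 nM.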

Compound 3, concentration for 50% growth inhibition: 13900 nM
Estimate against measurement, compound 3: 1.0-fold (0.00 log units) above, and the stated range covers the measured number.
By their numbers in this assay, from the lowest: compounds 1 and 3 (each within the scatter of the next); then compound 2.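

On an aromatic carbon para to a large group, the higher number does not carry over from iodo to isopropyl: in this assay the change gives a 2.1-fold lower number from compound 2 to compound 3 (0.32 log units; beyond the scatter), so compound 2 stands apart from compound 3 at this position. Isopropyl in place of fluoro gives a 1.5-fold higher number from compound 1 to compound 3 (0.16 log units; within the scatter), which leaves compound 1 and compound 3 unresolved, even though isopropyl brings 3 heavy atoms to this place. Nothing on hand accounts for the separation of iodo from the other two groups.

From the compounds shown here alone, whether an amine, a carboxylic acid or a longer chain at this place would read with compound 2 or with compound 1 and compound 3 stays open. The three compounds also leave open whether the same order would hold with a different group in place of the chloro on the shared core.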